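Trimming a methoxy from the most soluble compound

The compounds below may be only part of what the source reports. "The series", "measured", "known", "first", "only" and "open" are said of these compounds alone.

Among the measured compounds shown here, compound 2 `COc1cccc(Oc2ccc3c(NCCCNCc4cccc(OC)c4O)ccnc3c2)c1` holds the higher of the two numbers so far in a physicochemical assay for solubility, with a stated time of 18 h, at pH 7.4; a lower number here means a less soluble compound, a higher number a more soluble compound; compound 2 gives 14500 nM, while compound 1 `COc1cccc(CNCCCNc2ccnc3cc(Cc4ccccc4)ccc23)c1O` gives 4200 nM, and a 3.5-fold higher number from compound 1 to compound 2 (0.54 log units; beyond the scatter). Compound 3 `COc1cccc(CNCCCNc2ccnc3cc(Oc4ccccc4)ccc23)c1O` differs from compound 2 by hydrogen in place of methoxy on an aromatic carbon. For the measured compounds named here, no measured step concerns this kind of change, and the only measured step, a 3.5-fold higher number from compound 1 to compound 2 (0.54 log units; beyond the scatter), swaps a different group, so it gives no direct guide. Compound 3 is therefore expected to stay close to compound 2, with at most a small drop within the scatter, a 1.5-fold lower number from compound 2 to compound 3 (0.16 log units; within the scatter). The estimate for compound 3 is 10000 nM, ranging from 4000 nM to 25000 nM.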

Compound 3, solubility: 14500 nM
Estimate against measurement, compound 3: 1.5-fold (0.16 log units) below, and the stated range covers the measured number.
By their numbers in this assay, from the lowest: compound 1; then compounds 2 and 3 (each within the scatter of the next).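

In this assay, among the compounds shown here, taking the methoxy off the ring gives no change at the digits printed from compound 2 to compound 3 (within the scatter) and so, unlike the earlier compounds, shows that this place on the aromatic ring tolerates hydrogen as well as methoxy with no change beyond the scatter. Phenoxy in place of benzyl, with no methoxy involved, gives a 3.5-fold higher number from compound 1 to compound 3 (0.54 log units; beyond the scatter) and matches the size of a 3.5-fold higher number from compound 1 to compound 2 (0.54 log units; beyond the scatter) in the earlier pair. For the compounds shown here, no evidence on the compounds bears on this result. From the compounds shown here alone, whether an amine or a carboxylic acid at this same place would leave the number unchanged stays open.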